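Amino in place of methoxy: an unmeasured analogue of compound 1

The compounds below may be only part of what the source reports. "The series", "measured", "known", "first", "only" and "open" are said of these compounds alone.

Compound 1, `COc1ccc(-c2cn(-c3ccc(Oc4ccccc4)cc3)nn2)cc1`, gives > 100 nM in a functional assay on MDA-MB-231 cells (Homo sapiens) for cytotoxicity, read by MTT assay; a lower number here means a stronger inhibitor, a higher number a weaker inhibitor; this is a limit of the assay, not a number.
Compound 2, `COc1ccc(-c2cn(-c3cc(OC)c(OC)c(OC)c3)nn2)cc1`, gives > 10000 nM in this assay; this too is a limit, not a number.
Compound 3, `COc1ccc(-c2cn(-c3ccc(OC)cc3)nn2)cc1`, gives > 100 nM in this assay; again a limit, not a number.

Compound 1 therefore stands only at a limit, and the two other values shown are limits as well, two of them sitting at the limit of > 100 nM in this assay, at which 2 of the 3 values shown sit, and one at the limit of > 10000 nM in this assay, at which 1 of the 3 values shown sits. Among the compounds with values here, the one step between measured compounds that differ in a single place, a step that the two limits leave unreadable from compound 1 to compound 3, cannot be read because both ends are limits. Compound 4, `Nc1ccc(-c2cn(-c3ccc(Oc4ccccc4)cc3)nn2)cc1`, differs from compound 1 by amino in place of methoxy on an aromatic carbon. Within the data shown here, no measured step bears on this change, so no direction of change in this assay can be expected with any confidence, and the result may well again be a limit. Compound 4 is estimated at 3000 nM, within 300 nM to 30000 nM. The step so expected is a step that the limit leaves unreadable from compound 1 to compound 4.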

Compound 4, half-maximal inhibitory concentration: > 10000 nM
Compound 4: a limit, no number (the forecaster's own chance of this, stated with the estimate: 60%); middle value at least 3.3-fold (0.52 log units) away from the limit.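

Compound 1 and compound 4 both stand at limits in this assay, not at numbers, so the step between them cannot be read. The compounds shown leave open what amino in place of methoxy on an aromatic carbon does, since all four values are limits.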